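Swapping methyl for fluoro on the ethyl-linked ring

A few compounds are considered here, and "the series" means these few. Any claim that something is new, unique, unknown or untested is made for them only; others in the source may bear on it.

Among the measured compounds shown here, compound 2 `Cc1cc(CCOc2ccc(-c3c(C)nc(C)c([C@H](OC(C)(C)C)C(=O)O)c3N3CCC(C)(C)CC3)cc2)ccc1F` shares its core with compound 1 `Cc1nc(C)c([C@H](OC(C)(C)C)C(=O)O)c(N2CCC(C)(C)CC2)c1-c1ccc(Oc2ccccc2)cc1`, the only other measured member of this set. In a toxicity assay on MT2 cells (Homo sapiens) for cytotoxicity, read by XTT assay, with a stated time of 4 days (a lower number here means that less compound is tolerated, a higher number that more compound is tolerated), compound 1 reaches only a limit of >= 20000 nM. In this assay compound 2 likewise gives only a limit, >= 33500 nM. For the measured compounds named here, the single measured step, a step that the two limits leave unreadable from compound 1 to compound 2, has no readable size because the limit of >= 20000 nM in this assay, at which 1 of the 2 values shown sits, and the limit of >= 33500 nM in this assay, at which 1 of the 2 values shown sits, both sit at limits; compound 2 thus stands at a limit, and no order between the two compounds can be drawn.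

Compound 3 `Cc1nc(C)c([C@H](OC(C)(C)C)C(=O)O)c(N2CCC(C)(C)CC2)c1-c1ccc(OCCc2ccc(F)c(F)c2)cc1` differs from compound 2 by fluoro in place of methyl on an aromatic carbon. Going by the values given here, no measured step covers this change, and the one step available is unreadable, so the data give no expected size or direction beyond the scatter. Compound 3 is expected to behave like compound 2, with an estimated 33500 nM and a range from 15000 nM to 70000 nM, most likely reported again as a limit. The expected step is a number no higher from compound 2 to compound 3 (the limit leaves the size open).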

Compound 3, half-maximal cytotoxic concentration: >= 33500 nM
Compound 3 gave a limit, no number (the forecaster's own chance of this, stated with the estimate: 80%); the middle value lies on the limit itself.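

Among the compounds shown here, compound 1, compound 2 and compound 3 all give only limits in this assay, so no step among them can be read. The compounds shown leave open whether fluoro in place of methyl on the aromatic carbon changes the half-maximal cytotoxic concentration at all.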